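The source may hold more compounds than are shown below. What is called first, only, known or untested is meant among the compounds shown, and "the series" means these compounds.

Among the compounds with values here, in a functional assay on MCF-10A cells (Homo sapiens) for antiproliferative activity, with a stated time of 48 h (on this read-out lower numbers stand for an effect already at smaller amounts and higher numbers for an effect only at larger amounts of compound), compound 1 (`CCCCCCOc1ccc2nc(C)cc(NCc3ccc(F)cc3)c2c1`) gives 9100 nM and compound 2 (`CCCCCCCCOc1ccc2nc(C)cc(NCc3ccc(F)cc3)c2c1`) gives 2200 nM as the lower of the two numbers so far. Compound 3 (`Cc1cc(NCc2ccc(F)cc2)c2cc(OCCCCCCO)ccc2n1`) shares their core but has not yet been measured. It departs from compound 2 by hydroxy in place of ethyl on a saturated chain carbon, six bonds along the chain from an oxygen on an aromatic ring. Within the data shown here, only one measured step bears on this change. Ethyl in place of hydrogen on that same chain carbon came with a 4.1-fold lower number from compound 1 to compound 2 (0.62 log units; beyond the scatter) and that step is modest. Read backward, a 4.1-fold lower number from compound 1 to compound 2 (0.62 log units; beyond the scatter) suggests that compound 3, which gives up that ethyl, will move toward a higher number in this assay by a similar or somewhat larger step. Among the measured compounds shown here, no measured compound carries hydroxy, so what it adds on its own is unknown and the range must stay wide. The expected change is a 6.8-fold higher number from compound 2 to compound 3 (0.83 log units; beyond the scatter) on this reasoning. For compound 3 the estimated value is 15000 nM with an expected range from 5000 nM to 50000 nM in this measurement.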

Compound 3, half-maximal effective concentration: 11300 nM
The estimate for compound 3 lay 1.3-fold (0.12 log units) above the measured number, within the range that was stated.
By their numbers in this assay, from the lowest: compound 2; then compounds 1 and 3 (each within the scatter of the next).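

In this assay, hydroxy in place of ethyl on the saturated chain carbon, six bonds along the chain from an oxygen on an aromatic ring, brings a 5.1-fold higher number from compound 2 to compound 3 (0.71 log units; beyond the scatter), so the lower number seen with the ethyl does not survive this exchange. Hydroxy in place of hydrogen on that same carbon gives a 1.2-fold higher number from compound 1 to compound 3 (0.09 log units; within the scatter), which means that on this read-out hydroxy cannot be told apart from hydrogen, and of the three groups at this carbon only ethyl sets its compound apart. Nothing measured here accounts for this difference between ethyl and hydroxy.

The three compounds leave open whether the lower number belongs to ethyl in particular or would come with any further carbon chain at this place, and whether hydroxy would behave the same way at another point along the chain. An amine or a carboxylic acid on the same carbon, or a chain longer than that of compound 2, would test whether the hydroxy result extends to other groups and whether the trend seen with ethyl continues.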